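The source may report more compounds than this note shows. Statements on the series, on what has been measured and on what is new or still open speak of the compounds shown alone.

In a physicochemical assay for solubility, read by LC-MS, in phosphate buffer, with a stated time of 24 h, at pH 7.4 (a lower number here means a less soluble compound, a higher number a more soluble compound), compound 1, `Cn1cc(-c2cnc(NCc3c(F)ccc4c3CCO4)c3cn[nH]c(=O)c23)cn1`, gives 1000 nM. Compound 2, `CN(C)C(=O)c1cc(-c2cnc(NCc3c(F)ccc4c3CCO4)c3cn[nH]c(=O)c23)n(C)n1`, gives 3000 nM in this assay. Compound 3, `CN(c1ccccc1)c1cnc(NCc2c(F)ccc3c2CCO3)n2cnnc12`, gives in this assay only a limit, < 2000 nM, and not a number.

Compound 3 thus stands at the limit of < 2000 nM in this assay, at which 1 of the 3 values shown sits. Its place against compound 1 and compound 2 cannot be read as a step; only the limit is known for it.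

Compound 4, `Fc1ccc2c(c1CNc1ncc(Nc3ccccc3)c3nncn13)CCO2`, differs from compound 3 in one place: hydrogen in place of methyl on a nitrogen on an aromatic ring. For the measured compounds named here, the one measured step, a 3.0-fold higher number from compound 1 to compound 2 (0.48 log units; beyond the scatter), concerns a change of a different kind on an aromatic carbon and does not bear on the exchange of methyl for hydrogen on the ring nitrogen. Going by the values given here, with no measured step of the same kind to draw on, the expectation for compound 4 in this assay is a step that the limit leaves unreadable from compound 3 to compound 4, not beyond the scatter. Compound 4 is therefore estimated at 1500 nM, within 500 nM to 4000 nM, and a further limit reading is about as likely as a number.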

Compound 4, solubility: 3000 nM
Compound 4: middle estimate off by 2.0-fold (0.30 log units), on the low side; measured number inside the range.
By their numbers in this assay, from the lowest: compound 1; then compounds 2 and 4 (each within the scatter of the next).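

Exchanging methyl for hydrogen on a nitrogen on an aromatic ring, the change from methyl(phenyl)amino to anilino, gives in this assay an at least 1.5-fold higher number from compound 3 to compound 4 (0.17 log units; that floor lies within the scatter). For the compounds shown here, this is the first reading at this position, but it is only a floor, so the data do not show that the change moves the number beyond the scatter. Compound 3 gives a limit and not a number, and any other step from it cannot be read: the limit of < 2000 nM in this assay, at which 1 of the 4 values shown sits.

The true size of the step from methyl to hydrogen remains open, as no number is shown for the methyl compound. Also open, on these data alone, is how a longer chain such as ethyl on this nitrogen, or an amine or a carboxylic acid on the phenyl group, would read in this assay.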